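One more methoxy: from compound 2 to compound 3

The source may report more compounds than this note shows. Statements on the series, on what has been measured and on what is new or still open speak of the compounds shown alone.

In a functional assay on HepG2 cells (Homo sapiens) for antiproliferative activity, read by MTT assay, with a stated time of 48 h (on this read-out lower numbers stand for stronger inhibition and higher numbers for weaker inhibition), compound 1 (`COc1ccc(/C=C(\C#N)C(=O)N/N=C(\C)c2cc3cccc(OC)c3oc2=O)cc1`) gives 770 nM and compound 2 (`COc1ccc(/C=C(\C#N)C(=O)N/N=C(\C)c2cc3cccc(OC)c3oc2=O)cc1OC`) gives 930 nM as its reading. Within the data shown here, compound 2 therefore stands within the scatter of compound 1, its only measured neighbour, and the two numbers carry no ranking.

Compound 3 (`COc1cc(/C=C(\C#N)C(=O)N/N=C(\C)c2cc3cccc(OC)c3oc2=O)cc(OC)c1OC`) is still unmeasured. The structural change leading to it is methoxy in place of hydrogen on an aromatic carbon and amounts to methoxy in place of hydrogen on an aromatic carbon. The new group sits ortho to a methoxy group, meta to a methoxy group and meta to a large group.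

Among the measured compounds shown here, one measured step bears on this change, as the same replacement gave a 1.2-fold higher number from compound 1 to compound 2 (0.08 log units; within the scatter) and stayed within the scatter. For the measured compounds named here, a single step is thin evidence, and the new position has no measured precedent. Even so, no step beyond the scatter is expected in this assay and no direction is favoured. The estimated step is a 1.1-fold higher number from compound 2 to compound 3 (0.03 log units; within the scatter) and no more than that is expected. For compound 3 the expected value is 1000 nM with an estimated span from 450 nM to 2200 nM as the likely range.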

Compound 3, half-maximal inhibitory concentration: 1570 nM
For compound 3 the middle estimate is 1.6-fold (0.20 log units) below the measured one, and the stated range covers the measured number.
By their numbers in this assay, from the lowest: compounds 1, 2 and 3 (each within the scatter of the next, the first and the last beyond it).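

In this assay, methoxy in place of hydrogen on an aromatic carbon, placed ortho to a methoxy group, meta to a methoxy group and meta to a large group, gives a 1.7-fold higher number from compound 2 to compound 3 (0.23 log units; within the scatter), so this position now has a measured step of its own. Taken with a 1.2-fold higher number from compound 1 to compound 2 (0.08 log units; within the scatter), the same replacement has now been read at two places on this six-membered aromatic ring, and at neither does the step leave the scatter, so in this series the reading does not separate methoxy from hydrogen at either place. No measurement shown here offers an explanation for these two steps.

Both steps concern methoxy alone, so the compounds shown leave open whether a different group at this position, such as a hydroxy group, an amine or a carboxylic acid, or a longer chain such as ethoxy, would also stay within the scatter. Also open, going by these compounds, is whether hydrogen in place of the methoxy on the shared core would give a step of similar size in this assay.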